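This account rests on a few compounds, and the source may have more. Where it says the series, first, only, none or still open, it means among the compounds named here.

Compound 1 `Cc1nc(-c2ccc(C(F)(F)F)cc2)sc1CNc1ccc(CCCC(=O)O)cc1` gives in a functional assay on CHO cells for agonist activity at Free fatty acid receptor 1 (Homo sapiens) (a lower number here means that less compound is needed, a higher number that more compound is needed for the effect), a value of < 10000 nM, which is a limit of the assay and not a number.
Compound 2 `Cc1nc(-c2ccc(C(F)(F)F)cc2)sc1CNc1ccc(C(C)CC(=O)O)cc1` gives in this assay a value of 58.9 nM.
Compound 3 `Cc1nc(-c2ccc(C(F)(F)F)cc2)sc1CNc1ccc(CCC(N)=O)cc1` gives in this assay a value of 12.9 nM.

Compound 3 has the lowest of the two readable numbers; its nearest neighbour is compound 2, and the step of a 4.6-fold lower number from compound 2 to compound 3 (0.66 log units; beyond the scatter) lies beyond the scatter. The steps from compound 1 to compound 2 and from compound 1 to compound 3 cannot be sized, since compound 1 sits at a limit (the limit of < 10000 nM in this assay, at which 1 of the 3 values shown sits).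

Compound 4 `Cc1nc(-c2ccc(C(F)(F)F)cc2)sc1CNc1ccc([C@H]2C[C@@H]2C(=O)NC2CCNC2)cc1` differs from compound 3 in one place: 2-((pyrrolidin-3-yl)carbamoyl)cyclopropyl in place of 2-carbamoylethyl on an aromatic carbon. Among the measured compounds shown here, no measured step swaps the amide for a larger, ring-bearing amide; the only step that touches this chain, a 4.6-fold lower number from compound 2 to compound 3 (0.66 log units; beyond the scatter), exchanged an acid for a primary amide and was modest. Because the step of a 4.6-fold lower number from compound 2 to compound 3 (0.66 log units; beyond the scatter) shows this position to be sensitive, a change of this size is expected to move the number, most likely upward. Compound 4 is therefore estimated at 100 nM, with a range from 20 nM to 600 nM, a step of a 7.8-fold higher number from compound 3 to compound 4 (0.89 log units; beyond the scatter).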

Compound 4, half-maximal effective concentration: 204 nM
Compound 4: the middle estimate sits 2.0-fold (0.31 log units) below what was measured; low and high end bracket the measured number.
By their numbers in this assay, from the lowest: compound 3; then compound 2; then compound 4.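

Among the compounds shown here, compound 4 shows that this position still gives a readable number in this assay when it carries a group with two rings, whereas the earlier compounds held only open chains there. That enlargement comes at a cost against the primary amide, a 16-fold higher number from compound 3 to compound 4 (1.20 log units; beyond the scatter), a large step, while the step against the branched acid chain is only modest, a 3.5-fold higher number from compound 2 to compound 4 (0.54 log units; beyond the scatter). The step from compound 1 to compound 4 cannot be read, since the value of compound 1 is a limit of the assay: the limit of < 10000 nM in this assay, at which 1 of the 4 values shown sits.

Going by these compounds, the cyclopropyl ring and the pyrrolidine enter together, so the share of each in the step from the primary amide remains open. A primary amide or a carboxylic acid on the cyclopropyl ring, or a pyrrolidine amide on the open 2-carbamoylethyl chain, would begin to separate the two.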